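Swapping Ethyl for Nitro on the Amide Aryl Ring

The source may report more compounds than this note shows. Statements on the series, on what has been measured and on what is new or still open speak of the compounds shown alone.

Two compounds share one core and differ only in the group on the amide-bearing aryl ring. Compound 1 `COc1ccc(C(=O)Nc2cccc(-c3oc4cc(-c5ccc(F)cc5)ccc4c(=O)c3O)c2)cc1` carries a methoxy group; in a functional assay on MCF7 cells (Homo sapiens) for antiproliferative activity, read by CCK-8 assay, with a stated time of 72 h (on this read-out higher numbers stand for weaker inhibition and lower numbers for stronger inhibition), compound 1 gives 6250 nM. Compound 2 `CCc1ccc(C(=O)Nc2cccc(-c3oc4cc(-c5ccc(F)cc5)ccc4c(=O)c3O)c2)cc1` carries an ethyl group; in this assay compound 2 gives 22800 nM. Among the measured compounds shown here, the single step of a 3.6-fold higher number from compound 1 to compound 2 (0.56 log units; beyond the scatter) shows that this position matters, and it leaves compound 2 with the highest number of the two. Compound 3 `O=C(Nc1cccc(-c2oc3cc(-c4ccc(F)cc4)ccc3c(=O)c2O)c1)c1ccc([N+](=O)[O-])cc1` is the next step: nitro in place of ethyl on an aromatic carbon. For the measured compounds named here, no measured pair tells how nitro compares with ethyl here, so only the one step from compound 1 to compound 2 bears on it, and it was modest. A step of similar size is expected, a 2.9-fold lower number from compound 2 to compound 3 (0.45 log units; beyond the scatter), with direction uncertain. Compound 3 is therefore expected at 8000 nM, within 2500 nM to 25000 nM.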

Compound 3, half-maximal inhibitory concentration: 3970 nM
For compound 3 the middle estimate is 2.0-fold (0.30 log units) above the measured one; the measured number falls inside the stated range.
By their numbers in this assay, from the lowest: compounds 3 and 1 (each within the scatter of the next); then compound 2.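

Nitro brings the number back down from the ethyl level in this assay, a 5.7-fold lower number from compound 2 to compound 3 (0.76 log units; beyond the scatter), so the weak result of compound 2 does not extend to every replacement of methoxy at this position. The two non-ethyl groups cannot be ranked, since the step of a 1.6-fold lower number from compound 1 to compound 3 (0.20 log units; within the scatter) gives no real separation between nitro and methoxy. Among these three compounds, ethyl is the only group that stands apart, and nothing available here gives a reason for that difference.

From the compounds shown here alone, it remains open whether the weak result belongs to ethyl alone or also applies to methyl or a longer carbon chain. Going by these compounds, how an amine or a carboxylic acid would compare at this position also remains open.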